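The source may report more compounds than this note shows. Statements on the series, on what has been measured and on what is new or still open speak of the compounds shown alone.

Measured in a functional assay on A549 cells (Homo sapiens) for cytotoxicity, read by MTT assay, with a stated time of 72 h; a lower number here means a stronger inhibitor, a higher number a weaker inhibitor:
- Compound 1 `CSc1nc(Cl)c(C(=O)c2ccccc2)s1`: > 100000 nM (a limit of the assay, not a number)
- Compound 2 `O=C(c1ccccc1)c1sc(N2CCCC2)nc1Cl`: 50000 nM
- Compound 3 `O=C(c1ccccc1)c1sc(N2CCCC2)nc1Br`: 97000 nM

Only two of these results are true numbers: compound 2 at 50000 nM and compound 3 at 97000 nM, which lie within the scatter of each other. Compound 4 `O=C(c1ccccc1)c1sc(N2CCCCC2)nc1Cl` keeps the core of compound 2 but has piperidin-1-yl in place of pyrrolidin-1-yl on an aromatic carbon.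

Among the compounds with values here, no measured step makes this exact swap. The nearest guide is an at least 2.0-fold lower number from compound 1 to compound 2 (0.30 log units; that floor lies within the scatter), which changes the group at the same place, but its size is only a floor and lies within the scatter. The other step, a 1.9-fold higher number from compound 2 to compound 3 (0.29 log units; within the scatter), exchanges chloro for bromo and is also within the scatter. Neither gives a reason to expect a real shift in this assay, so no step beyond the scatter is expected. The estimated result is a 1.1-fold lower number from compound 2 to compound 4 (0.05 log units; within the scatter). For compound 4 the expected value is 45000 nM, with an estimated range of 18000 nM to 100000 nM.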

Compound 4, half-maximal inhibitory concentration: 41000 nM
Estimate against measurement, compound 4: 1.1-fold (0.04 log units) above, within the range that was stated.
By their numbers in this assay, from the lowest: compounds 4, 2 and 3 (each within the scatter of the next, the first and the last beyond it). At a limit, above all of these: compound 1.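

Going from the five-membered pyrrolidin-1-yl to the six-membered piperidin-1-yl on this aromatic carbon gives a 1.2-fold lower number from compound 2 to compound 4 (0.09 log units; within the scatter), so this change in ring size leaves no readable effect in the assay. Within the data shown here, putting piperidin-1-yl in place of methylsulfanyl at the same carbon gives an at least 2.4-fold lower number from compound 1 to compound 4 (0.38 log units; beyond the scatter), which shows for the first time a step at this position that clears the scatter. That size is only a floor, since compound 1 stands at a limit and not at a true number: the limit of > 100000 nM in this assay, at which 1 of the 4 values shown sits.

Still open, on these data alone, is how an open-chain amine such as diethylamino, or a ring amine with a second hetero atom such as morpholin-4-yl, would compare at this carbon. Also open, as far as these compounds go, is whether any group here could bring the number far below those of compound 2 and compound 4.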